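A few compounds are considered here, and "the series" means these few. Any claim that something is new, unique, unknown or untested is made for them only; others in the source may bear on it.

In a functional assay on MCF7 cells (Homo sapiens) for cytotoxicity, read by MTT assay, with a stated time of 24 h (a higher number here means a weaker inhibitor, a lower number a stronger inhibitor), three compounds have been measured so far:
compound 1 `CN(C)CCN1CCN(CC(=O)Nc2ccc(-c3nc4cc(Cl)ccc4o3)cc2)CC1`, 7920 nM;
compound 2 `CN(C)CCN1CCN(CC(=O)Nc2ccc(-c3nc4ccccc4o3)cc2)CC1`, 59400 nM;
compound 3 `CN(C)CCCN1CCN(CC(=O)Nc2ccc(-c3nc4ccccc4o3)cc2)CC1`, 23400 nM.

Compound 4 `CN(C)CCCN1CCN(CC(=O)Nc2ccc(-c3nc4cc(Cl)ccc4o3)cc2)CC1` has not yet been measured in this assay. It differs from compound 3 by chloro in place of hydrogen on an aromatic carbon. The same change has already been made once among these compounds, from compound 2 to compound 1, where it reads chloro in place of hydrogen on an aromatic carbon and gave a 7.5-fold lower number from compound 2 to compound 1 (0.88 log units; beyond the scatter). The two cores on which this change is made differ by (dimethylamino)methyl in place of dimethylamino on a saturated chain carbon, two bonds along the chain from an amine nitrogen in a ring, a difference that gave a 2.5-fold lower number from compound 2 to compound 3 (0.40 log units; beyond the scatter). Because the same change gave a 7.5-fold lower number from compound 2 to compound 1 (0.88 log units; beyond the scatter) on the other core, and its place is described in the same words on both cores, compound 4 is expected to show a step of about a 7.3-fold lower number from compound 3 to compound 4 (0.86 log units; beyond the scatter) in this assay. Compound 4 is therefore estimated at 3200 nM. For compound 4 the expected range runs from 1200 nM to 8500 nM.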

Compound 4, half-maximal inhibitory concentration: 1650 nM
Compound 4: the middle estimate sits 1.9-fold (0.29 log units) above what was measured; measured number inside the range.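

In this assay the chloro change carried over to the second core, giving a 14-fold lower number from compound 3 to compound 4 (1.15 log units; beyond the scatter), and its two readings agree: the same change on two cores in this assay, a 7.5-fold lower number (0.88 log units; beyond the scatter) from compound 2 to compound 1 and a 14-fold lower number (1.15 log units; beyond the scatter) from compound 3 to compound 4, 1.9-fold (0.28 log units) apart, within the scatter of two such steps. The chain change also carried over to the chloro core, giving a 4.8-fold lower number from compound 1 to compound 4 (0.68 log units; beyond the scatter), and its two readings agree as well: the same change on two cores in this assay, a 2.5-fold lower number (0.40 log units; beyond the scatter) from compound 2 to compound 3 and a 4.8-fold lower number (0.68 log units; beyond the scatter) from compound 1 to compound 4, 1.9-fold (0.28 log units) apart, within the scatter of two such steps. Within these four compounds the two changes therefore behave as roughly independent steps, but this rests on a single pair of cores and does not show that the chloro step would keep its size on any other core.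

The compounds shown leave open whether bromo or methoxy in place of the chloro would give a similar step. They also leave open whether a longer chain would lower the number further.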